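This account rests on a few compounds, and the source may have more. Where it says the series, first, only, none or still open, it means among the compounds named here.

Measured so far in an ADME assay on CCRF-HSB-2 cells (Homo sapiens) for cytotoxicity, with a stated time of 7 days; a higher number here means that more compound is tolerated, a lower number that less compound is tolerated:
compound 1 `CCCCCCCCOc1nc(N)nc2c1ncn2/C=C1/CC1(CO)CO` gives > 20000 nM, which is a limit of the assay.
compound 2 `Nc1nc(OCC(F)(F)F)c2ncn(/C=C3/CC3(CO)CO)c2n1` gives > 20000 nM, which is also a limit of the assay.
compound 3 `CCCCCCCCSc1nc(N)nc2c1ncn2/C=C1/CC1(CO)CO` gives 60000 nM.

Compound 1 therefore stands only at a limit of this assay, not at a number, so its place relative to the other two values cannot be fixed. The three measured steps, a step that the two limits leave unreadable from compound 1 to compound 2, a step that the limit leaves unreadable from compound 1 to compound 3 and a step that the limit leaves unreadable from compound 2 to compound 3, are all unreadable in size and direction, because of the limit of > 20000 nM in this assay, at which 2 of the 3 values shown sit. Among the compounds with values here, what the series does show is that every compound tested so far is tolerated up to the limit or beyond it in this assay.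

Compound 4 `Nc1nc(NC2CCCC2)c2ncn(/C=C3/CC3(CO)CO)c2n1` is not yet measured. Compared with compound 1 the change is as follows:
cyclopentylamino in place of octyloxy on an aromatic carbon
The steps from compound 1 to compound 2 and from compound 1 to compound 3 alter the same aromatic carbon, and each of those steps is unreadable, so they give no sign of a measurable step at this position. No step beyond the scatter is expected in this assay; compound 4 is expected to be tolerated much as the shown compounds are, most likely again reported as a limit. The estimate for compound 4 is 40000 nM, with a range from 15000 nM to 150000 nM. This estimate means a step that the limit leaves unreadable from compound 1 to compound 4 from compound 1, which is expected to stay within the scatter.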

Compound 4, half-maximal cytotoxic concentration: > 20000 nM
Compound 4 was reported as a limit; the forecaster's own chance of this, stated with the estimate: 60%; the middle value does not contradict the limit.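

In this assay compound 4 gives > 20000 nM, which is a limit of the assay. Its steps to compound 1, compound 2 and compound 3 therefore cannot be read in size or direction: the limit of > 20000 nM in this assay, at which 3 of the 4 values shown sit.

The compounds shown leave open whether any of these groups on the aromatic carbon shifts the tolerated concentration in this assay beyond the usual scatter.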